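The source may report more compounds than this note shows. Statements on the series, on what has been measured and on what is new or still open speak of the compounds shown alone.

Of the compounds shown here, two built on one shared core have been measured in a functional assay on NCI-H460 cells (Homo sapiens) for antiproliferative activity, with a stated time of 72 h; on this read-out higher numbers stand for weaker inhibition and lower numbers for stronger inhibition. Compound 1, `C=CC[C@H]1C[C@]2(CCc3ccc(OC)c(OC)c3)OCOC2=CC1=O`, is the weaker of the pair: in this assay compound 1 gives 3200 nM. Compound 2, `C=CC[C@H]1C[C@]2(C(C)Cc3ccc(OCC)cc3)OCOC2=CC1=O`, gives 280 nM in this assay, the lowest of the two numbers recorded, and its separation from compound 1 is well beyond the usual scatter, so compound 2 can be called the more potent of the two.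

The next compound, compound 3, `C=CC[C@H]1C[C@]2(C(C)Cc3ccc(F)cc3)OCOC2=CC1=O`, keeps everything in compound 2 except one position on the aromatic ring, where the change is fluoro in place of ethoxy on an aromatic carbon. For the measured compounds named here, no pair of measured compounds differs by this exchange alone, so these data give no direct guide to its size. A fluoro group is smaller than an ethoxy group and brings no hydrogen-bond acceptor, and such a swap on an aromatic ring is often modest in effect. The expectation is therefore a small step upward, toward weaker inhibition, that may not exceed the scatter: for compound 3 the estimated value is 500 nM, within a range from 150 nM to 1700 nM, which corresponds to an expected step of a 1.8-fold higher number from compound 2 to compound 3 (0.25 log units; within the scatter).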

Compound 3, half-maximal inhibitory concentration: > 20000 nM
Compound 3: a limit, no number; the forecaster's own chance of this, stated with the estimate: 3%; middle value at least 40-fold (1.60 log units) away from the limit.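

In this assay compound 3 gives > 20000 nM, which is a limit of the assay and not a number. Replacing ethoxy with fluoro on this aromatic carbon, para to a large group, gives an at least 71-fold higher number from compound 2 to compound 3 (1.85 log units; beyond the scatter), so a change at this single place on the ring can matter greatly, which compound 1 and compound 2 could not show on their own, as they differ in more than one place. The step therefore has a lower bound but no exact size, and its upper end is open, with compound 3 resting on a limit: the limit of > 20000 nM in this assay, at which 1 of the 3 values shown sits.

What stays open is how much of the ethoxy group this position needs, as the compounds shown offer only one comparison at this carbon. A hydroxyl, an amine or a longer chain such as propoxy in the same place would help show whether the oxygen, the length of the chain or both go with the lower number of compound 2.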